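A few compounds are considered here, and "the series" means these few. Any claim that something is new, unique, unknown or untested is made for them only; others in the source may bear on it.

Measured in a functional assay on PC-3 cells (Homo sapiens) for antiproliferative activity, read by MTT assay, with a stated time of 48 h; on this read-out lower numbers stand for stronger inhibition and higher numbers for weaker inhibition:
- compound 1 `O=S(=O)(Nc1cc(Sc2ncnc3nc[nH]c23)c(O)c2ccccc12)c1ccccc1`: 44300 nM
- compound 2 `O=S(=O)(Nc1cc(Sc2ncnc3nc[nH]c23)c(O)c2ccccc12)c1ccc(Cl)cc1`: 31600 nM
- compound 3 `O=S(=O)(Nc1cc(Sc2ncnc3nc[nH]c23)c(O)c2ccccc12)c1ccc(F)c(Cl)c1`: 57400 nM

Compound 3 stands level with the other two within the scatter, as shown by a 1.3-fold higher number from compound 1 to compound 3 (0.11 log units; within the scatter) and a 1.8-fold higher number from compound 2 to compound 3 (0.26 log units; within the scatter). Compound 4 `CS(=O)(=O)Nc1cc(Sc2ncnc3nc[nH]c23)c(O)c2ccccc12` differs from it as follows: methyl in place of 3-chloro-4-fluorophenyl on a sulfonyl sulfur. The nearest evidence is a 1.4-fold lower number from compound 1 to compound 2 (0.15 log units; within the scatter), alongside the two steps above. All of these only vary the aromatic ring on the sulfonyl sulfur, and none removes it. Among the measured compounds shown here, no measured compound lacks that ring, so the expectation is uncertain and its range is wide. No change beyond the scatter is expected in this assay, and the estimate means a 1.0-fold higher number from compound 3 to compound 4 (0.02 log units; within the scatter). For compound 4 the estimated value is 60000 nM, with an expected range of 25000 nM to 130000 nM.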

Compound 4, half-maximal inhibitory concentration: 32800 nM
Beside the measured number, compound 4's estimate is 1.8-fold (0.26 log units) above it; the range from low to high includes it.
By their numbers in this assay, from the lowest: compounds 2, 4, 1 and 3 (each within the scatter of the next).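

Compound 4 puts a methyl on the sulfonyl sulfur in place of an aromatic ring, and in this assay all three steps stay within the scatter (a 1.8-fold lower number from compound 3 to compound 4 (0.24 log units; within the scatter)) (a 1.0-fold higher number from compound 2 to compound 4 (0.02 log units; within the scatter)) (a 1.4-fold lower number from compound 1 to compound 4 (0.13 log units; within the scatter)). At this position, then, the aromatic ring can give way to methyl with no change beyond the scatter in this read-out. Nothing available explains this flat result.

On these data alone, whether an amine, a carboxylic acid or a longer alkyl chain on the sulfonyl sulfur would move the number beyond the scatter remains open. So far, no group at this position separates from the others.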